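Cytotoxicity notes on a bridged-ring aryl series

The compounds below may be only part of what the source reports. "The series", "measured", "known", "first", "only" and "open" are said of these compounds alone.

Compound 1 `c1ccc([C@@H]2C[C@@H]3Cc4ccc5ccccc5c4N2O3)cc1`: 72900 nM
Compound 2 `Fc1ccc([C@@H]2C[C@@H]3Cc4ccc5ccccc5c4N2O3)cc1`: > 300000 nM
Compound 3 `Clc1cccc([C@@H]2C[C@@H]3Cc4ccc5ccccc5c4N2O3)c1`: > 300000 nM

In an ADME assay on Vero cells (Chlorocebus sabaeus) for cytotoxicity, read by MTT assay, with a stated time of 72 h (on this read-out lower numbers stand for higher toxicity in this test and higher numbers for lower toxicity in this test), compound 1 gives 72900 nM. For compound 2 the value > 300000 nM is a limit of the assay, not a number. For compound 3 the value > 300000 nM is likewise a limit. Compound 3 thus stands only at a limit in this assay, as shown by the limit of > 300000 nM in this assay, at which 2 of the 3 values shown sit. The steps of an at least 4.1-fold higher number from compound 1 to compound 2 (0.61 log units; beyond the scatter) and an at least 4.1-fold higher number from compound 1 to compound 3 (0.61 log units; beyond the scatter) both run up to that limit, while a step that the two limits leave unreadable from compound 2 to compound 3 cannot be read. Compound 4 `Clc1ccc([C@@H]2C[C@@H]3Cc4ccc5ccccc5c4N2O3)c(Cl)c1` differs from compound 3 by 2,4-dichlorophenyl in place of 3-chlorophenyl on a saturated ring carbon. Among the measured compounds shown here, no measured step covers a second chloro, but both halogenated compounds sit at the limit. Compound 4 is expected to stay there, so a number no higher from compound 3 to compound 4 (the limit leaves the size open) is expected to show no change beyond the scatter. The estimate for compound 4 is 300000 nM, in the range 150000 nM to 600000 nM.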

Compound 4, half-maximal cytotoxic concentration: 55000 nM
Compound 4: middle estimate off by 5.5-fold (0.74 log units), on the high side; the measured number lies below the stated range.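

On the saturated ring carbon next to the ring nitrogen, halogen on the aryl group does not by itself hold the number at the limit in this assay: 2,4-dichlorophenyl gives an at least 5.4-fold lower number from compound 3 to compound 4 (0.73 log units; beyond the scatter) and an at least 5.4-fold lower number from compound 2 to compound 4 (0.73 log units; beyond the scatter). Against plain phenyl there is only a 1.3-fold lower number from compound 1 to compound 4 (0.12 log units; within the scatter), so the two cannot be told apart in this test.

Which chloro of the 2,4-dichlorophenyl group carries the drop stays open, and a 2-chlorophenyl group would help separate the two. Also open, on these data alone, is how an amine or a carboxylic acid on this aryl ring would read.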